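The compounds below may be only part of what the source reports. "The series", "measured", "known", "first", "only" and "open" are said of these compounds alone.

Measured compounds:
Compound 1, `O[C@H](c1ccccn1)[C@]1(c2ccc(C(F)(F)F)cc2)C[C@@H](O)C1`, in an ADME assay on liver for metabolic stability, with Liver microsome (Homo sapiens) as the target, read by LC-MS, using microsomes, with a stated time of 5 h (on this read-out lower numbers stand for slow clearance and higher numbers for fast clearance), compound 1 gives 33.3 mL/min/kg.
Compound 2, `C[C@@]1(c2ccc(OC(F)(F)F)cc2)C[C@@](O)(c2ccccn2)CO1`, in this assay compound 2 gives 66.7 mL/min/kg.

Within the data shown here, compound 2 sits at the top of these two numbers, but its only neighbour, compound 1, falls within the usual scatter of it, so the two cannot really be told apart on clearance. Compound 3, `C[C@]1(c2ccc(OC(F)(F)F)cc2)C[C@@](O)(c2ccccn2)CO1`, has not yet been measured. It is related to compound 2 as follows: the two compounds have the same atoms and bonds and differ only in configuration as drawn: 1 of 2 stereo elements differ; a stereocentre at a saturated ring carbon is drawn S in compound 2 and R in compound 3. Among the measured compounds shown here, since compounds 1 and 2 differ in many places at once, no single-change step is available to show how a flip at one ring carbon moves clearance in this assay. The expectation is therefore a step of no size beyond the scatter, in no particular direction. Compound 3 is estimated to give 60 mL/min/kg. For compound 3 the expected range runs from 30 mL/min/kg to 120 mL/min/kg. This estimate corresponds to an expected step of a 1.1-fold lower number from compound 2 to compound 3 (0.05 log units; within the scatter).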

Compound 3, clearance: 117 mL/min/kg
For compound 3 the middle estimate is 2.0-fold (0.29 log units) below the measured one, within the range that was stated.
By their numbers in this assay, from the lowest: compounds 1, 2 and 3 (each within the scatter of the next, the first and the last beyond it).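

This pair gives the first single-change step among the compounds shown, isolating one stereocentre at a saturated ring carbon: in this assay the flip from S to R gives a 1.8-fold higher number from compound 2 to compound 3 (0.24 log units; within the scatter). That step lies within the usual scatter of repeated measurements, so the two configurations at this carbon cannot be told apart on clearance, and no clear sensitivity to the flip appears here. Any real gap between the two could trace to only one thing: the fact that compounds 2 and 3 differ only in the configuration as drawn.

As far as these compounds go, what a flip at the other stereo element would do to clearance stays open. So does whether this carbon would remain as indifferent to its configuration with an amine or a carboxylic acid carried on the shared core.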